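Triazole to Ethynyl: Expected Shift in Dog Liver Microsome Clearance

The source may report more compounds than this note shows. Statements on the series, on what has been measured and on what is new or still open speak of the compounds shown alone.

Measured compounds:
Compound 1, `CC1SC(c2cccc(C(=O)NCCCCc3ccccc3)c2)N(c2ccc(C3CC3)cc2)C1=O`: 1750 mL.min-1.g-1
Compound 2, `O=C(NCCCCc1ccccc1)c1cccc(C2SCC(=O)N2c2cccc(-c3c[nH]nn3)c2)c1`: 226 mL.min-1.g-1

Going by the values given here, compound 2 stands at the lowest of the two numbers in an ADME assay on microsomes from liver (Canis lupus familiaris) for metabolic stability, read by LC-MS, using NADPH, with a stated time of 10 min, tested at 0.1 uM; a lower number here means slower removal, a higher number faster removal of the compound; its only neighbour, compound 1, gives a number that is higher by a margin beyond the usual scatter. Compound 1 differs from compound 2 in more than one place, so those two values alone do not show which change drives the difference.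

Compound 3, `C#Cc1cccc(N2C(=O)CSC2c2cccc(C(=O)NCCCCc3ccccc3)c2)c1`, is not yet measured. It differs from compound 2 in one place: ethynyl in place of 1H-1,2,3-triazol-4-yl on an aromatic carbon.

Among the compounds with values here, no measured pair shows this exact change, so the direction has to be judged from what the two values reveal. Within the data shown here, the only compound without the triazole, compound 1, sits at the higher number, and compound 2 with the triazole sits at the lower one. On that basis a rise is expected for compound 3 in this assay, of moderate size, though with wide uncertainty.

Compound 3 is expected to give about 600 mL.min-1.g-1 in this assay, within a range of 250 mL.min-1.g-1 to 1500 mL.min-1.g-1, which corresponds to an expected step of a 2.7-fold higher number from compound 2 to compound 3 (0.42 log units; beyond the scatter).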

Compound 3, intrinsic clearance in microsomes: 973 mL.min-1.g-1
Beside the measured number, compound 3's estimate is 1.6-fold (0.21 log units) below it; the measured number falls inside the stated range.
By their numbers in this assay, from the lowest: compound 2; then compounds 3 and 1 (each within the scatter of the next).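

In this assay, putting ethynyl in place of 1H-1,2,3-triazol-4-yl gives a 4.3-fold higher number from compound 2 to compound 3 (0.63 log units; beyond the scatter), so removal of the compound is faster with ethynyl at this position. Compounds 2 and 3 differ in one place only, which ties this rise to a single aromatic carbon, meta to a large group, whereas the several differences between compounds 1 and 2 could not be separated. The change still alters several things at once, since the five-membered aromatic ring with 3 hetero atoms, its 1 hydrogen-bond donor and its 2 hydrogen-bond acceptors all leave together, and nothing available here explains why the number rises.

The pair cannot tell whether the lower number of compound 2 depends on the triazole ring as a whole or on its hydrogen-bond donor, a question that a triazole carrying a methyl group on a ring nitrogen could address. As far as these compounds go, it also remains open whether other groups at this position, such as a nitrile, a primary amide or a carboxylic acid, would sit nearer to compound 2 or to compound 3.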